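A few compounds are considered here, and "the series" means these few. Any claim that something is new, unique, unknown or untested is made for them only; others in the source may bear on it.

Values in a functional assay on HMEC-1 cells (Homo sapiens) for antiproliferative activity, read by cell counting, with a stated time of 4 days; on this read-out lower numbers stand for stronger inhibition and higher numbers for weaker inhibition:
- compound 1 `COc1ccc(Oc2ccccc2NC(C)=C2C(=O)CC(c3ccccc3)CC2=O)cc1`: 83 nM
- compound 2 `CC(Nc1ccccc1Oc1ccccc1)=C1C(=O)CC(c2ccccc2)CC1=O`: 160 nM
- compound 3 `COc1cc(Oc2ccccc2NC(C)=C2C(=O)CC(c3ccccc3)CC2=O)ccc1N`: 29 nM

Compound 3 has the lowest number of the three, and both steps leading to it lie beyond the scatter: a 2.9-fold lower number from compound 1 to compound 3 (0.46 log units; beyond the scatter) and a 5.5-fold lower number from compound 2 to compound 3 (0.74 log units; beyond the scatter). The next compound to consider is compound 4 `CC(Nc1ccccc1Oc1ccc(C(C)O)cc1)=C1C(=O)CC(c2ccccc2)CC1=O`, where 4-(1-hydroxyethyl)phenyl stands in place of 4-amino-3-methoxyphenyl on an oxygen on an aromatic ring: 4-(1-hydroxyethyl)phenyl in place of 4-amino-3-methoxyphenyl on an oxygen on an aromatic ring.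

For the measured compounds named here, no measured compound carries the entering group, so its own contribution is unknown. The closest evidence is what the leaving group has been worth. Both modest steps above reach compound 3 by installing 4-amino-3-methoxyphenyl, so compound 4 is expected to give up some or all of that gain. The remaining step in the set, a 1.9-fold higher number from compound 1 to compound 2 (0.29 log units; within the scatter), stays within the scatter, so a single methoxy on the phenyl gives no clear signal. On that basis, a step of similar modest size towards a higher number is expected in this assay, which would put compound 4 close to the values of the two less active compounds. The expected step is a 2.9-fold higher number from compound 3 to compound 4 (0.47 log units; beyond the scatter). For compound 4 the estimated value is 85 nM, with an expected range of 30 nM to 240 nM.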

Compound 4, half-maximal inhibitory concentration: 140 nM
For compound 4 the middle estimate is 1.6-fold (0.22 log units) below the measured one; the measured number falls inside the stated range.
By their numbers in this assay, from the lowest: compound 3; then compounds 1, 4 and 2 (each within the scatter of the next).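

In this assay, the step of a 4.8-fold higher number from compound 3 to compound 4 (0.68 log units; beyond the scatter) shows that the gain at this aryl group on the oxygen does not carry over to 4-(1-hydroxyethyl)phenyl, even though it has the same heavy-atom count and hydrogen-bond donor count as 4-amino-3-methoxyphenyl. On the aromatic carbon, 1-hydroxyethyl cannot be told apart from hydrogen, with the step of a 1.1-fold lower number from compound 2 to compound 4 (0.06 log units; within the scatter) within the scatter, or from methoxy, with the step of a 1.7-fold higher number from compound 1 to compound 4 (0.23 log units; within the scatter) also within the scatter, so compound 3 alone stands clear of the other three compounds. Nothing available here explains the difference between the two aryl groups.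

From the compounds shown here alone, what remains open is whether the amine alone or the amine together with the methoxy accounts for the lower number of compound 3, a question that 4-aminophenyl and 3-methoxyphenyl on the same oxygen would address. Also open, going by these compounds, is how a carboxylic acid or a longer chain in place of 1-hydroxyethyl would read out in this assay on this same core.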